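Ester variation on a shared core: cytotoxicity working notes

This account rests on a few compounds, and the source may have more. Where it says the series, first, only, none or still open, it means among the compounds named here.

Measured so far:
compound 1 `CCC(CC)C(=O)OCc1cccc2c1CCOC2=O` — 1890000 nM
compound 2 `O=C(OCc1cccc2c1CCOC2=O)c1ccc([N+](=O)[O-])cc1` — > 2260000 nM

In an ADME assay on HepG2 2.2.15 cells (Homo sapiens) for cytotoxicity, read by MTT assay, with a stated time of 72 h (a lower number here means that less compound is tolerated, a higher number that more compound is tolerated), compound 1 gives 1890000 nM. Compound 2 returns only a limit of the assay, > 2260000 nM, and no number. Among the compounds with values here, compound 1 therefore stands as the sole numerical value in this assay; the other entry is the limit, (the limit of > 2260000 nM in this assay, at which 1 of the 2 values shown sits).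

Compound 3 `O=C(OCc1cccc2c1CCOC2=O)c1ccco1` is not yet measured in this assay. It differs from compound 1 in one place: furan-2-yl in place of pentan-3-yl on a carbonyl carbon whose other neighbour is the oxygen next to the carbonyl group. Within the data shown here, no step between measured compounds is available to calibrate this change.

The expectation is that the step from compound 1 to compound 3 in this assay stays within the scatter, with no clear direction, as given by a 1.1-fold higher number from compound 1 to compound 3 (0.02 log units; within the scatter). For compound 3 the estimated value in this assay is 2000000 nM, with a range from 1000000 nM to 4000000 nM. A limit rather than a number is a real possibility, because compound 2 already sits at the limit of > 2260000 nM in this assay, at which 1 of the 2 values shown sits.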

Compound 3, half-maximal cytotoxic concentration: > 2350000 nM
Compound 3: a limit, no number (the forecaster's own chance of this, stated with the estimate: 50%); at least 1.1-fold (0.07 log units) between middle value and limit.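

Working notes, position on the carbonyl carbon: in this assay, furan-2-yl in place of pentan-3-yl gives an at least 1.2-fold higher number from compound 1 to compound 3 (0.09 log units; that floor lies within the scatter), so this change has a floor but no measured size. Compound 3 gives > 2350000 nM, which is a limit of the assay and not a number. With compound 3, a second variation at this position ends in a limit rather than a number, and compound 1 remains the only compound with a numerical value: the limit of > 2350000 nM in this assay, at which 1 of the 3 values shown sits.

The true size of the change from pentan-3-yl to furan-2-yl cannot be read, and the two limits do not allow compound 3 to be placed relative to compound 2. Also open, going by these compounds, is whether a ring without aromatic character, such as cyclopentyl, or a chain carrying an amine, on the same carbonyl carbon would give a number in this assay, which would show whether a numerical value is tied to the open-chain pentan-3-yl group of compound 1.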